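Trading 4-fluorophenyl for thiophen-3-yl

The source may hold more compounds than are shown below. What is called first, only, known or untested is meant among the compounds shown, and "the series" means these compounds.

In a functional assay on HepG2 cells (Homo sapiens) for antiproliferative activity, read by MTT assay, with a stated time of 48 h (on this read-out lower numbers stand for stronger inhibition and higher numbers for weaker inhibition), compound 1 `CC(=O)N1N=C(c2ccc3ccccc3c2)OC1c1ccccc1F` gives 3.36 ug/mL and compound 2 `CC(=O)N1N=C(c2ccc3ccccc3c2)OC1c1ccc(F)cc1` gives 1.82 ug/mL. Among the compounds with values here, these are the only two numbers so far, and they lie within the scatter of each other, so compound 2 cannot be told apart from compound 1. The next molecule, compound 3 `CC(=O)N1N=C(c2ccc3ccccc3c2)OC1c1ccsc1`, keeps the shared core but carries thiophen-3-yl in place of 4-fluorophenyl on a saturated ring carbon. Within the data shown here, only one measured step offers any guide, the shift of the fluorine, a 1.8-fold lower number from compound 1 to compound 2 (0.27 log units; within the scatter), and it stayed within the scatter. Among the measured compounds shown here, it is a weak guide, since no measured compound yet carries a five-membered aromatic ring at this place. Starting from compound 2 at 1.82 ug/mL, no change beyond the scatter is expected, and the estimated step is a 1.4-fold higher number from compound 2 to compound 3 (0.14 log units; within the scatter). For compound 3 the expected value is 2.5 ug/mL, with an estimated range of 1 ug/mL to 6.5 ug/mL.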

Compound 3, half-maximal inhibitory concentration: 6.82 ug/mL
Estimate against measurement, compound 3: 2.7-fold (0.44 log units) below; measured number outside the range, above it.
By their numbers in this assay, from the lowest: compounds 2 and 1 (each within the scatter of the next); then compound 3.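

The two earlier compounds differed only in where the fluorine sat on the phenyl ring, and that shift stayed within the scatter, so they could not show whether this saturated ring carbon responds to its group at all. Exchanging the whole aromatic ring shows that it does: in this assay, the change to thiophen-3-yl gives a 3.7-fold higher number from compound 2 to compound 3 (0.57 log units; beyond the scatter) and a 2.0-fold higher number from compound 1 to compound 3 (0.31 log units; beyond the scatter), both modest but beyond the scatter, which leaves compound 3 the weakest of the three. No measurement shown here explains why this ring exchange weakens inhibition.

Still open, on these data alone, is whether the weakening goes with the five-membered ring or with the absence of fluorine, a question that an unsubstituted phenyl group at this place could help to separate. Also open, as far as these compounds go, is how this position would respond to a group of a different kind, such as an amine or a carboxylic acid.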